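Amide side chains: from compound 3 to compound 4

The source may report more compounds than this note shows. Statements on the series, on what has been measured and on what is new or still open speak of the compounds shown alone.

Measured compounds:
- compound 1 `CCn1c(C(=O)NCCC(=O)OC)ccc1C(CC)(CC)c1ccc(OCS(=O)(=O)c2ccccc2)c(C)c1` gives > 50000 nM as a limit
- compound 2 `CCn1c(C(=O)NC2(CO)CC2)ccc1C(CC)(CC)c1ccc(OCS(=O)(=O)c2ccccc2)c(C)c1` gives 45400 nM as a number
- compound 3 `CCn1c(C(=O)N[C@@H](CO)CCCO)ccc1C(CC)(CC)c1ccc(OCS(=O)(=O)c2ccccc2)c(C)c1` gives 16400 nM as a number

In a functional assay on BXPC-3 cells (Homo sapiens) for antiproliferative activity, read by MTT assay, with a stated time of 24 h (a lower number here means a stronger inhibitor, a higher number a weaker inhibitor), compound 3 has the lowest number of the three. Compound 1 is known only as a limit. Compound 4 `CCn1c(C(=O)N[C@H](C)C(=O)O)ccc1C(CC)(CC)c1ccc(OCS(=O)(=O)c2ccccc2)c(C)c1` carries 1-carboxyethyl on the amide-type nitrogen in place of the chain of compound 3 (a group of 5 heavy atoms (3 carbon, 2 oxygen; no ring) in place of a group of 7 heavy atoms (5 carbon, 2 oxygen; no ring), on an amide-type nitrogen). Among the measured compounds shown here, two measured steps bear on this change: a 2.8-fold lower number from compound 2 to compound 3 (0.44 log units; beyond the scatter) and an at least 3.0-fold lower number from compound 1 to compound 3 (0.48 log units; beyond the scatter) in the same direction. By contrast, an at least 1.1-fold lower number from compound 1 to compound 2 (0.04 log units; that floor lies within the scatter) stays within the scatter. Both other chains, in compound 1 and compound 2, give higher numbers than compound 3, so a modest rise is expected. The estimated change is a 1.8-fold higher number from compound 3 to compound 4 (0.26 log units; within the scatter) toward weaker inhibition. Compound 4 is expected at 30000 nM within an estimated range of 12000 nM to 50000 nM in this series.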

Compound 4, half-maximal inhibitory concentration: 20100 nM
Estimate against measurement, compound 4: 1.5-fold (0.17 log units) above; measured number inside the range.
By their numbers in this assay, from the lowest: compounds 3 and 4 (each within the scatter of the next); then compound 2. At a limit, above all of these: compound 1.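

In this assay, a shorter chain on the amide-type nitrogen, 1-carboxyethyl, is not separated from the chain it replaces: a 1.2-fold higher number from compound 3 to compound 4 (0.09 log units; within the scatter). The same group does stand clear of 1-(hydroxymethyl)cyclopropyl, with a 2.3-fold lower number from compound 2 to compound 4 (0.35 log units; beyond the scatter). Against 2-(methoxycarbonyl)ethyl, an at least 2.4-fold lower number from compound 1 to compound 4 (0.39 log units; beyond the scatter) is only a floor, because compound 1 is known only as a limit: the limit of > 50000 nM in this assay, at which 1 of the 4 values shown sits.

Going by these compounds, what the methyl ester of 1-carboxyethyl, an amine in place of its carboxylic acid, or a longer carboxylic acid chain would give stays open. On these data alone, the opposite configuration at the 1-carboxyethyl stereocentre is also open.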